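Series notes: replacing the aminophenyl arm with piperidinyl

The source may report more compounds than this note shows. Statements on the series, on what has been measured and on what is new or still open speak of the compounds shown alone.

Measured so far:
compound 1 `Nc1cccc(CNc2cc(C(F)(F)F)cc3[nH]ncc23)c1` gives 89%
compound 2 `O=C(O)CNc1cccc(CNc2cc(C(F)(F)F)cc3[nH]ncc23)c1` gives 65%
compound 3 `CNC(=O)c1cccc(CNc2cc(C(F)(F)F)cc3[nH]ncc23)c1` gives 91%

All three numbers come from an assay for inhibition of Tryptophan 2,3-dioxygenase (Homo sapiens), with stated times of 10 min and 60 min, tested at 100 uM; on this read-out higher numbers stand for a stronger effect at the one concentration tested and lower numbers for a weaker effect. Compound 1 stands second of the three, with compound 3 within the scatter of it, and compound 2 the only one separated from it, by a number 24 percentage points lower from compound 1 to compound 2 (beyond the scatter). The other steps, a number 2 percentage points higher from compound 1 to compound 3 (within the scatter) and a number 26 percentage points higher from compound 2 to compound 3 (beyond the scatter), likewise concern only the substituent on the phenyl ring.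

Compound 4 `FC(F)(F)c1cc(NC[C@@H]2CCCCN2)c2cn[nH]c2c1` differs from compound 1 in another way: piperidin-2-yl in place of 3-aminophenyl on a saturated chain carbon bound to a nitrogen on an aromatic ring. Among the compounds with values here, no measured step touches the ring itself, so the three steps bear on this change only loosely; they show that altering the group on that ring costs little or a modest amount. The expected step is therefore a modest drop, a number 29 percentage points lower from compound 1 to compound 4 (beyond the scatter), with a wide range. Compound 4 is estimated at 60%, between 25% and 88%.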

Compound 4, a percentage reported as inhibition, at one concentration (the size of the read-out at that concentration, not a potency): 88%
Compound 4: middle estimate off by 28 percentage points, on the low side; the range from low to high includes it.
By their numbers in this assay, from the lowest: compound 2; then compounds 4, 1 and 3 (each within the scatter of the next).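

In this assay exchanging the whole aromatic arm, not merely a substituent on it, gives a number 1 percentage points lower from compound 1 to compound 4 (within the scatter) and leaves the read-out unchanged within the scatter. At this saturated chain carbon, an aromatic ring is therefore not required for this level of effect at the one concentration tested, since the non-aromatic piperidin-2-yl serves as well as 3-aminophenyl. No available data explain why the two arms read alike.

On these data alone, the opposite form of the defined stereocentre remains open. So do a pyrrolidinyl ring and an open-chain amine in place of piperidin-2-yl.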